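Aryl amide variation on the shared sulfonylacetamide core

The source may hold more compounds than are shown below. What is called first, only, known or untested is meant among the compounds shown, and "the series" means these compounds.

Measured compounds:
compound 1, `Cc1ccc(NC(=O)CS(=O)(=O)c2nccc(Oc3c(C)cc(C#N)cc3C)n2)cc1C`, 13900 nM
compound 2, `Cc1cc(C#N)cc(C)c1Oc1ccnc(S(=O)(=O)CC(=O)Nc2ccccc2F)n1`, 28400 nM
compound 3, `Cc1cc(C#N)cc(C)c1Oc1ccnc(S(=O)(=O)CC(=O)Nc2cccc(Cl)c2)n1`, 25400 nM

In an ADME assay on MT4 cells (Homo sapiens) for cytotoxicity, read by MTT assay, with a stated time of 4 days (on this read-out higher numbers stand for lower toxicity in this test and lower numbers for higher toxicity in this test), compound 3 holds the second highest of the three numbers, yet its gaps to compound 2 and to compound 1 both lie within the scatter. Compound 4, `Cc1cc(C#N)cc(C)c1Oc1ccnc(S(=O)(=O)CC(=O)Nc2ccc([N+](=O)[O-])cc2)n1`, differs from compound 3 by 4-nitrophenyl in place of 3-chlorophenyl on an amide-type nitrogen. The measured steps bearing on this are the other aryl swaps on the same amide-type nitrogen: a 2.0-fold higher number from compound 1 to compound 2 (0.31 log units; beyond the scatter), a 1.8-fold higher number from compound 1 to compound 3 (0.26 log units; within the scatter) and a 1.1-fold lower number from compound 2 to compound 3 (0.05 log units; within the scatter). Only one of these leaves the scatter, and only modestly. For compound 4 a step of comparable size is therefore expected, a 1.0-fold lower number from compound 3 to compound 4 (0.01 log units; within the scatter), most likely none beyond the scatter. Compound 4 is estimated at 25000 nM, with a range from 12000 nM to 50000 nM.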

Compound 4, half-maximal cytotoxic concentration: 59600 nM
Compound 4: middle estimate off by 2.4-fold (0.38 log units), on the low side; measured number outside the range, above it.
By their numbers in this assay, from the lowest: compounds 1, 3 and 2 (each within the scatter of the next, the first and the last beyond it); then compound 4.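

In this assay 4-nitrophenyl on this amide-type nitrogen gives a 2.3-fold higher number from compound 3 to compound 4 (0.37 log units; beyond the scatter) and a 2.1-fold higher number from compound 2 to compound 4 (0.32 log units; beyond the scatter) and also a 4.3-fold higher number from compound 1 to compound 4 (0.63 log units; beyond the scatter) across the aryl groups shown. Among the earlier aryl swaps only one step left the scatter, whereas compound 4 stands clear of all three other compounds and holds the highest number of the four.

From the compounds shown here alone, how an aminophenyl or a carboxyphenyl on the same nitrogen would read remains open. No measured property shown here accounts for the step.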